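A few compounds are considered here, and "the series" means these few. Any claim that something is new, unique, unknown or untested is made for them only; others in the source may bear on it.

Three compounds have been measured in an ADME assay on cells (Peritoneal macrophage, Mus musculus, strain Balb/c) for cytotoxicity, read by resazurin assay, with a stated time of 72 h; a higher number here means that more compound is tolerated, a lower number that less compound is tolerated:

compound 1 `CC1(Cc2ccccc2C(F)(F)F)CC(S(=O)(=O)c2ccc(F)cc2)=C(c2ccc(/C(N)=N/O)cc2)O1`, 105000 nM
compound 2 `CC1(Cc2cccc([N+](=O)[O-])c2)CC(S(=O)(=O)c2ccc(F)cc2)=C(c2ccc(/C(N)=N/O)cc2)O1`, 86600 nM
compound 3 `COc1ccc(CC2(C)CC(S(=O)(=O)c3ccc(F)cc3)=C(c3ccc(/C(N)=N/O)cc3)O2)cc1`, > 100000 nM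

For compound 3 the value in this assay is a limit of the assay, not a number, as the line the limit of > 100000 nM in this assay, at which 1 of the 3 values shown sits, records. Compound 4 `Cc1cccc(CC2(C)CC(S(=O)(=O)c3ccc(F)cc3)=C(c3ccc(/C(N)=N/O)cc3)O2)c1` differs from compound 3 by 3-methylphenyl in place of 4-methoxyphenyl on a saturated chain carbon bound to a saturated ring carbon. The steps measured at this position were a 1.2-fold lower number from compound 1 to compound 2 (0.08 log units; within the scatter) and an at least 1.1-fold higher number from compound 2 to compound 3 (0.06 log units; that floor lies within the scatter); the step that the limit leaves unreadable from compound 1 to compound 3 cannot be sized. Neither readable step exceeds the scatter, so the step of a number no higher from compound 3 to compound 4 (the limit leaves the size open) is expected to stay within the scatter in this assay. Compound 4 is therefore estimated to give 100000 nM in this assay, between 50000 nM and 200000 nM.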

Compound 4, half-maximal cytotoxic concentration: 112000 nM
Compound 4: the middle estimate sits 1.1-fold (0.05 log units) below what was measured; the range from low to high includes it.
By their numbers in this assay, from the lowest: compounds 2, 1 and 4 (each within the scatter of the next).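

In this assay, methyl in place of nitro gives a 1.3-fold higher number from compound 2 to compound 4 (0.11 log units; within the scatter), and 3-methylphenyl in place of 2-(trifluoromethyl)phenyl gives a 1.1-fold higher number from compound 1 to compound 4 (0.03 log units; within the scatter). A phenyl ring carrying only a methyl group therefore joins the nitro and trifluoromethyl compounds within the scatter at this position. Compound 3 stands at a limit of the assay, so its step to compound 4 cannot be read: the limit of > 100000 nM in this assay, at which 1 of the 4 values shown sits.

From the compounds shown here alone, it remains open whether an amine, a carboxylic acid or a longer chain at this position would move the number in this assay beyond the scatter.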